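A pyridin-3-yl group on the ring amine of the shared core

The compounds below may be only part of what the source reports. "The series", "measured", "known", "first", "only" and "open" are said of these compounds alone.

Three compounds with a shared core were measured in a functional assay on CHO cells with adenosine receptor A1 (Homo sapiens) as the target, read by cAMP accumulation and immunoassay, with a stated time of 6 min, tested at 10 uM; a lower number here means a stronger effect, a higher number a weaker effect of the compound at the concentration tested:
Compound 1 `Nc1scc(CN2CCN(c3cc(Cl)cc(Cl)c3)CC2)c1C(=O)c1ccc(Cl)cc1` gives -74%.
Compound 2 `Nc1scc(CN2CCN(c3ccc(Cl)c(C(F)(F)F)c3)CC2)c1C(=O)c1ccc(Cl)cc1` gives -60%.
Compound 3 `Nc1scc(CN2CCN(c3ccc(OC(F)(F)F)cc3)CC2)c1C(=O)c1ccc(Cl)cc1` gives -74%.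

Compound 3 stands level with compound 1, together the lowest of the three numbers, with no change at the digits printed from compound 1 to compound 3 (within the scatter); compound 2 is the furthest from it, with a number 14 percentage points lower from compound 2 to compound 3 (beyond the scatter), and a number 14 percentage points higher from compound 1 to compound 2 (beyond the scatter).

Compound 4 `Nc1scc(CN2CCN(c3cccnc3)CC2)c1C(=O)c1ccc(Cl)cc1` differs from compound 3 in one place: pyridin-3-yl in place of 4-(trifluoromethoxy)phenyl on an amine nitrogen in a ring. Within the data shown here, no measured step covers this exchange; the steps seen among the three measured compounds were modest or within the scatter, so a modest step, if any, is expected in this assay, more likely toward a higher number than a lower one: a number 16 percentage points higher from compound 3 to compound 4 (beyond the scatter) is the expected step. Compound 4 is therefore estimated at -58%, with a range from -80% to -28%.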

Compound 4, a percentage reported as activity, at one concentration (the size of the read-out at that concentration, not a potency): -23%
Estimate against measurement, compound 4: 35 percentage points below; measured number above the stated range.
By their numbers in this assay, from the lowest: compounds 1 and 3 (each within the scatter of the next); then compound 2; then compound 4.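

Among the earlier compounds, exchanging one substituted phenyl group for another on this amine nitrogen gave modest steps or none, but pyridin-3-yl, the first ring here with a hetero atom, gives large ones: a number 51 percentage points higher from compound 3 to compound 4 (beyond the scatter), a number 37 percentage points higher from compound 2 to compound 4 (beyond the scatter) and a number 51 percentage points higher from compound 1 to compound 4 (beyond the scatter). In this assay, this position therefore responds far more to this exchange than to any change among the phenyl groups. Nothing at hand bears on the reason for this.

The exchange both puts a nitrogen into the ring and removes the substituents, and these compounds do not separate the two. An unsubstituted phenyl or a chloro-substituted pyridin-3-yl would bear on that question.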